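Phenyl in Place of Methyl, Tried a Second Time

The source may report more compounds than this note shows. Statements on the series, on what has been measured and on what is new or still open speak of the compounds shown alone.

Compound 1: `C=C(C)C(=O)c1ccc(OCc2nc(C)no2)cc1Cl`, 2100 nM
Compound 2: `C=C(C)C(=O)c1ccc(OCc2nc(-c3ccccc3)no2)cc1Cl`, 600 nM
Compound 3: `C=C(CC)C(=O)c1ccc(OCc2nc(C)no2)c(Cl)c1Cl`, 4000 nM

These three compounds were tested in an assay on HL-60 cells for inhibition of glutathione S-transferase P (Homo sapiens); on this read-out lower numbers stand for stronger inhibition and higher numbers for weaker inhibition. Compound 1 gives 2100 nM there, and compound 2 gives 600 nM. Compound 2 differs from compound 1 in one place: phenyl in place of methyl on an aromatic carbon. This change brought a 3.5-fold lower number from compound 1 to compound 2 (0.54 log units; beyond the scatter). Compound 3 gives 4000 nM in this assay; its gap to compound 1 lies within the scatter, while its gap to compound 2 is beyond it. The difference between the core of compound 1 and the core of compound 3 is not broken down here.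

Compound 4, `C=C(CC)C(=O)c1ccc(OCc2nc(-c3ccccc3)no2)c(Cl)c1Cl`, has not yet been measured. It stands to compound 3 as compound 2 stands to compound 1: phenyl in place of methyl on an aromatic carbon. The place of the change reads the same in both cases, so this is the same change made on a different core. With a single earlier example, the expectation is that the change will again bring a step of similar size, namely a 3.3-fold lower number from compound 3 to compound 4 (0.52 log units; beyond the scatter), resting on the measured 3.5-fold lower number from compound 1 to compound 2 (0.54 log units; beyond the scatter). On that basis compound 4 is expected to give about 1200 nM in this assay, estimated between 500 nM and 3000 nM.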

Compound 4, half-maximal inhibitory concentration: 3600 nM
The estimate for compound 4 lay 3.0-fold (0.48 log units) below the measured number; measured number above the stated range.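

On the second core, in this assay, phenyl in place of methyl gave a 1.1-fold lower number from compound 3 to compound 4 (0.05 log units; within the scatter), so the clear gain seen on the first core did not carry over. Among these compounds, the two steps are truly different, not just two noisy readings of one effect: the same change on two cores in this assay, a 3.5-fold lower number (0.54 log units; beyond the scatter) from compound 1 to compound 2 and a 1.1-fold lower number (0.05 log units; within the scatter) from compound 3 to compound 4, 3.2-fold (0.50 log units) apart, beyond the scatter of two such steps This shows that the size of the step measured on one core cannot simply be transferred to another core, but with only one pair on each core, it does not show which of the differences between the cores matters, or why.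

Still open, on these data alone, is how the step would behave on a core that carries only one of those differences, which would help to locate where the loss arises. As far as these compounds go, it is also open whether another group at the same place on the five-membered ring, such as an amine or a longer chain, would depend on the core in the same way.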